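From 1,2-Dihydroxyethyl to 2-Hydroxypropyl on the Chain

The compounds below may be only part of what the source reports. "The series", "measured", "known", "first", "only" and "open" are said of these compounds alone.

Compound 1, `OCC(O)Cn1nc2c(Br)c(Br)c(Br)c(Br)c2n1`, stands as the weakest of the three measured in a functional assay on MCF7 cells (Homo sapiens) for antiproliferative activity, read by MTT assay, with a stated time of 24 h, tested at 12.5 uM; on this read-out higher numbers stand for a weaker effect at the one concentration tested and lower numbers for a stronger effect: compound 1 gives 145%, whereas compound 2, `OC(CCn1nc2c(Br)c(Br)c(Br)c(Br)c2n1)c1ccc(Br)cc1`, gives 82% and compound 3, `OC(CCn1nc2c(Br)c(Br)c(Br)c(Br)c2n1)c1ccccc1`, gives 115%. Within the data shown here, the only single-point step between measured compounds, a number 33 percentage points higher from compound 2 to compound 3 (beyond the scatter), involves a bromo on an aromatic carbon and so does not speak to the side chain. Compound 4, `C[C@H](O)CCn1nc2c(Br)c(Br)c(Br)c(Br)c2n1`, differs from compound 1 by 2-hydroxypropyl in place of 1,2-dihydroxyethyl on a saturated chain carbon bound to an aromatic nitrogen. Among the measured compounds shown here, no measured pair alters this chain, so no step bears directly on the change. Only a modest move toward a stronger effect is expected, a number 20 percentage points lower from compound 1 to compound 4 (beyond the scatter), little beyond the scatter. Compound 4 is estimated at 125%, between 95% and 155%.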

Compound 4, a percentage reported as activity, at one concentration (the size of the read-out at that concentration, not a potency): 112%
For compound 4 the middle estimate is 13 percentage points above the measured one; the range from low to high includes it.
By their numbers in this assay, from the lowest: compound 2; then compounds 4 and 3 (each within the scatter of the next); then compound 1.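

Replacing 1,2-dihydroxyethyl with 2-hydroxypropyl on a saturated chain carbon bound to an aromatic nitrogen gives a number 33 percentage points lower from compound 1 to compound 4 (beyond the scatter) in this assay, so this position can shift the read-out even with the core unchanged. Among these compounds, the change trades an oxygen for a carbon and adds a defined stereocentre, and the single step cannot separate these two differences. No available evidence accounts for the shift. Still open, going by these compounds, is how a plain propyl chain would compare, and whether a chain ending in an amine or a carboxylic acid would move the number further.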